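Swapping a piperidine arm for a trifluoroacetamide on a shared core

The compounds below may be only part of what the source reports. "The series", "measured", "known", "first", "only" and "open" are said of these compounds alone.

Of the compounds shown here, three built on one core have been measured in a physicochemical assay for solubility, read by HPLC, with a stated time of 24 h; a higher number here means a more soluble compound, a lower number a less soluble compound. Compound 1, `O=C1O[C@@H](CO)CN1c1ccc(-n2cc(-c3ccccn3)cn2)c(F)c1`, gives 56400 nM. Compound 2, `COC(=O)CC1CCN(C[C@H]2CN(c3ccc(-n4cc(-c5ccccn5)cn4)c(F)c3)C(=O)O2)CC1`, gives 92100 nM, the second highest of the three numbers and within the scatter of compound 1. Compound 3, `CN(C)S(=O)(=O)NC[C@H]1CN(c2ccc(-n3cc(-c4ccccn4)cn3)c(F)c2)C(=O)O1`, gives 472000 nM. The step of an 8.4-fold higher number from compound 1 to compound 3 (0.92 log units; beyond the scatter) and the step of a 5.1-fold higher number from compound 2 to compound 3 (0.71 log units; beyond the scatter) show that replacing the group on the saturated chain carbon bound to a saturated ring carbon can move the number beyond the scatter, while the step of a 1.6-fold higher number from compound 1 to compound 2 (0.21 log units; within the scatter) stays within it.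

Compound 4, `O=C1O[C@@H](CNC(=O)C(F)(F)F)CN1c1ccc(-n2cc(-c3ccccn3)cn2)c(F)c1`, is made from compound 2 by the change (((trifluoromethyl)carbonyl)amino in place of 4-((methoxycarbonyl)methyl)piperidin-1-yl on a saturated chain carbon bound to a saturated ring carbon). The entering group, like the (dimethylsulfamoyl)amino group of compound 3, carries one hydrogen-bond donor and is smaller than the group it replaces, so the step of a 5.1-fold higher number from compound 2 to compound 3 (0.71 log units; beyond the scatter) is the closest guide. A modest rise is therefore expected, a 2.2-fold higher number from compound 2 to compound 4 (0.34 log units; beyond the scatter), giving an estimated value for compound 4 of 200000 nM, with a range from 80000 nM to 500000 nM.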

Compound 4, solubility: 114000 nM
Beside the measured number, compound 4's estimate is 1.8-fold (0.24 log units) above it; the measured number falls inside the stated range.
By their numbers in this assay, from the lowest: compounds 1, 2 and 4 (each within the scatter of the next, the first and the last beyond it); then compound 3.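

In this assay, placing ((trifluoromethyl)carbonyl)amino where 4-((methoxycarbonyl)methyl)piperidin-1-yl stood gives a 1.2-fold higher number from compound 2 to compound 4 (0.09 log units; within the scatter), so at this position losing the piperidine ring and gaining a hydrogen-bond donor do not alone reproduce the number of compound 3. Changing only the group on the amine nitrogen, with (trifluoromethyl)carbonyl in place of dimethylsulfamoyl, gives a 4.1-fold lower number from compound 3 to compound 4 (0.62 log units; beyond the scatter), which shows that the high number of compound 3 does not come from the amine nitrogen alone. Against the hydroxy group, the same entering group gives a 2.0-fold higher number from compound 1 to compound 4 (0.31 log units; beyond the scatter), a modest step that sits just beyond the scatter.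

No measurement shown explains why these groups differ. From the compounds shown here alone, it remains open whether a plain acetyl or a methanesulfonyl group on the same amine nitrogen would read closer to compound 4 or to compound 3.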